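Swapping the aryl group on the thioether chain

The compounds below may be only part of what the source reports. "The series", "measured", "known", "first", "only" and "open" are said of these compounds alone.

Compound 2 `COc1cccc(C(C)Sc2nc3c(cnn3C)c(=O)n2-c2ccccc2)c1` is the weaker of the two measured compounds in an assay on isolated protein for inhibition of aldehyde dehydrogenase 1A1 (Homo sapiens) (a lower number here means a stronger inhibitor, a higher number a weaker inhibitor), where compound 2 gives 451 nM. Its nearest neighbour in the set is compound 1 `C[C@@H](Sc1nc2c(cnn2C)c(=O)n1-c1ccccc1)c1ccccc1`, which in this assay gives 70 nM; the gap between these two numbers lies beyond the usual scatter. Within the data shown here, no single-point step between measured compounds has been recorded, so nothing measured tells how a change at this position plays out.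

Compound 3 `CC(Sc1nc2c(cnn2C)c(=O)n1-c1ccccc1)c1ccncc1` differs from compound 2 by pyridin-4-yl in place of 3-methoxyphenyl on a saturated chain carbon bound to a saturated chain carbon and a sulfur. Among the measured compounds shown here, with no measured step to lean on, the expectation for compound 3 rests on the two measured values alone: compound 2 gives 451 nM while compound 1 gives 70 nM. Compound 3 is expected to land closer to the lower of these two, with an estimated step of a 2.8-fold lower number from compound 2 to compound 3 (0.45 log units; beyond the scatter). For compound 3 the estimate in this assay is 160 nM, within a range of 40 nM to 650 nM.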

Compound 3, half-maximal inhibitory concentration: 451 nM
The estimate for compound 3 lay 2.8-fold (0.45 log units) below the measured number; the measured number falls inside the stated range.
By their numbers in this assay, from the lowest: compound 1; then compounds 2 and 3 (each within the scatter of the next).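

Among these compounds, the first step at this position, no change at the digits printed from compound 2 to compound 3 (within the scatter) in this assay, shows that pyridin-4-yl and 3-methoxyphenyl on this saturated chain carbon cannot be told apart in this read-out, even though the two groups differ in ring atoms and heavy-atom count. Among the compounds shown here, the step of a 6.4-fold higher number from compound 1 to compound 3 (0.81 log units; beyond the scatter) shows that exchanging 1-phenylethyl for 1-(pyridin-4-yl)ethyl on the sulfur does not keep the number of compound 1, so the lower number so far belongs to the only compound of the three with an unsubstituted phenyl. Nothing measured here accounts for either result.

The compounds shown leave open whether a pyridin-3-yl or a 4-methoxyphenyl group would stay with compound 2 and compound 3 or come closer to compound 1. For the compounds shown here, they also leave open what the single configuration drawn for compound 1 contributes.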